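The source may report more compounds than this note shows. Statements on the series, on what has been measured and on what is new or still open speak of the compounds shown alone.

Measured in a functional assay on isolated protein for inhibition of Glucose-dependent insulinotropic receptor (Rattus norvegicus), read by HTRF and cAMP accumulation; on this read-out lower numbers stand for an effect already at smaller amounts and higher numbers for an effect only at larger amounts of compound:
compound 1, `Cc1nc(S(C)(=O)=O)ccc1Oc1ncnc(OC2CCN(C(=O)OC(C)(C)C(F)(F)F)CC2)c1F`, gives 47.2 nM
compound 2, `Cc1nc(S(C)(=O)=O)ccc1Oc1ncnc(OC2CCN(C(=O)O[C@H](C)C(F)(F)F)CC2)c1F`, gives 110 nM
compound 3, `Cc1nc(S(C)(=O)=O)ccc1Oc1ncnc(OC2CCN(C(=O)OC3COC3)CC2)c1F`, gives 2500 nM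

Compound 3 stands at the highest number of the three in this assay. Both other compounds lie far below it: a 53-fold higher number from compound 1 to compound 3 (1.72 log units; beyond the scatter) and a 23-fold higher number from compound 2 to compound 3 (1.36 log units; beyond the scatter). The two fluorinated carbamates themselves differ only modestly, a 2.3-fold higher number from compound 1 to compound 2 (0.37 log units; beyond the scatter).

Compound 4, `Cc1nc(S(C)(=O)=O)ccc1Oc1ncnc(OC2CCN(C(=O)SC3CC3)CC2)c1F`, differs from compound 3 by a group of 4 heavy atoms (3 carbon, 1 sulfur; one three-membered non-aromatic ring of carbon only) in place of a group of 5 heavy atoms (3 carbon, 2 oxygen; one four-membered non-aromatic ring with 1 hetero atom), on a carbonyl carbon. Going by the values given here, no measured pair shows this exact exchange. Among the compounds with values here, the steps that bear on it are the two that brought in the oxetan-3-yl group, a 53-fold higher number from compound 1 to compound 3 (1.72 log units; beyond the scatter) and a 23-fold higher number from compound 2 to compound 3 (1.36 log units; beyond the scatter), both large and both raising the number. Compound 4 no longer carries that group, and a lower number than compound 3 is expected because the steps of a 53-fold higher number from compound 1 to compound 3 (1.72 log units; beyond the scatter) and a 23-fold higher number from compound 2 to compound 3 (1.36 log units; beyond the scatter) tie the high number of compound 3 to the oxetan-3-yl group. The entering group matches neither measured carbamate, so only part of the drop is expected to be recovered. Compound 4 is expected at about 300 nM, with a range from 80 nM to 1200 nM. The expected step is an 8.3-fold lower number from compound 3 to compound 4 (0.92 log units; beyond the scatter).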

Compound 4, half-maximal effective concentration: 126 nM
Compound 4: middle estimate off by 2.4-fold (0.38 log units), on the high side; the range from low to high includes it.
By their numbers in this assay, from the lowest: compound 1; then compounds 2 and 4 (each within the scatter of the next); then compound 3.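

On the carbonyl carbon, fluorine turns out not to be required for a low number in this assay: compound 3 and compound 4 both lack it, yet exchanging (oxetan-3-yl)oxy for the sulfur-bearing group with its three-membered carbon ring gives a large step (a 20-fold lower number from compound 3 to compound 4 (1.30 log units; beyond the scatter)). This group, which has no fluorine, stands level with the 1-(trifluoromethyl)ethyl carbamate (a 1.1-fold higher number from compound 2 to compound 4 (0.06 log units; within the scatter)), while a modest gap remains to the carbamate with 1-methyl-1-(trifluoromethyl)ethyl (a 2.7-fold higher number from compound 1 to compound 4 (0.43 log units; beyond the scatter)), so the position accepts groups of quite different make-up without the number rising to that of compound 3. Nothing available here accounts for these differences.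

The atom bound to the carbonyl carbon and the ring change together between compound 3 and compound 4, so the compounds shown cannot divide the step between sulfur and the three-membered ring. Going by these compounds, it also remains open how a cyclopropyl group joined through oxygen, a cyclobutyl group joined through sulfur or a plain tert-butyl group joined through oxygen would read out at this position.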